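Dropping the Fluorine from Compound 1's Biaryl Tail

The compounds below may be only part of what the source reports. "The series", "measured", "known", "first", "only" and "open" are said of these compounds alone.

Measured so far:
- compound 1 `CCCc1c(OCCCOc2cc(O)c(-c3ccc(F)cc3)cc2CC)ccc2c1OC(C(=O)O)CC2` gives 4.4 nM
- compound 2 `CCc1cc(-c2ccc(F)cc2)c(O)cc1OCCCOc1ccccc1CCC(=O)O` gives 3.8 nM

Both numbers come from an assay on membranes from lung (Cavia porcellus) for binding affinity to leukotriene B4 receptor (Homo sapiens), read by radioligand binding; on this read-out lower numbers stand for stronger inhibition and higher numbers for weaker inhibition. Compound 1 has the higher of the two numbers, but the gap to compound 2 lies within the scatter, so the two compounds cannot be told apart on these data. Among the compounds with values here, compound 2 carries a different acid head from compound 1, and no step between the pair is charted, so nothing beyond their two values can be read from them.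

The unmeasured compound 3 `CCCc1c(OCCCOc2cc(O)c(-c3ccccc3)cc2CC)ccc2c1OC(C(=O)O)CC2` keeps the whole of compound 1 apart from one change: hydrogen in place of fluoro on an aromatic carbon. Within the data shown here, no step of this kind has been measured, so any expectation rests on the single value of compound 1. Because compound 1 gives 4.4 nM, and a lone fluorine on an outer aromatic ring is a small change, compound 3 is expected to stay close, with at most a modest drift toward a higher number; the step from compound 1 to compound 3 is estimated at a 1.6-fold higher number from compound 1 to compound 3 (0.20 log units; within the scatter). In this assay compound 3 is estimated at 7 nM, within a range from 2.5 nM to 20 nM.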

Compound 3, inhibition constant: 2.8 nM
The estimate for compound 3 lay 2.5-fold (0.40 log units) above the measured number; the range from low to high includes it.
By their numbers in this assay, from the lowest: compounds 3, 2 and 1 (each within the scatter of the next).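

Going from 4-fluorophenyl to phenyl is the only step in this series that changes a single place, and in this assay it reads as a 1.6-fold lower number from compound 1 to compound 3 (0.20 log units; within the scatter). The step lies within the scatter, so compound 1 and compound 3 cannot be told apart, and at this aromatic carbon, para to a large group, the fluoro group shows no measurable contribution to the value on these data: hydrogen serves as well within the resolution of the measurement. Nothing available bears on the reason for this outcome.

The compounds shown leave open whether this tolerance extends beyond the pair fluoro and hydrogen, since they give no reading at this carbon for a larger or differently built group such as chlorine, methoxy, trifluoromethyl or an amine. Within the data shown here, they also leave open whether the same change would read alike on compound 2, which carries a different acid head, as no pair built on that compound is charted.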